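Chloro to methoxy: the step to compound 3

This account rests on a few compounds, and the source may have more. Where it says the series, first, only, none or still open, it means among the compounds named here.

Values in an ADME assay on HaCaT cells (Homo sapiens) for inhibition, read by sulforhodamine B assay, with a stated time of 48 h; on this read-out lower numbers stand for stronger inhibition of growth and higher numbers for weaker inhibition of growth:
Compound 1 (`CC(C)(C)NCc1c(C(=O)O)nn(-c2ccccc2)c1-c1ccc(Cl)cc1`): > 652000 nM as a limit
Compound 2 (`CC(C)(C)NCc1c(C(=O)O)nn(-c2ccc(Cl)cc2)c1-c1ccc(Cl)cc1`): 87500 nM as a number

Within the data shown here, compound 2 holds the only actual number in this assay so far. The entry for compound 1 is a limit.

Compound 3 (`COc1ccc(-c2c(CNC(C)(C)C)c(C(=O)O)nn2-c2ccc(Cl)cc2)cc1`) follows from compound 2 through one change (methoxy in place of chloro on an aromatic carbon): methoxy in place of chloro on an aromatic carbon, that is, 4-chlorophenyl to 4-methoxyphenyl.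

Among the measured compounds shown here, only one measured step bears on this, and only indirectly. It is an at least 7.4-fold lower number from compound 1 to compound 2 (0.87 log units; beyond the scatter) and came with chloro in place of hydrogen on an aromatic carbon. It starts from the limit of > 652000 nM in this assay, at which 1 of the 2 values shown sits, and so gives only a bound. For the measured compounds named here, compound 1 already carries the 4-chlorophenyl group, so no measured step touches the chloro that leaves here.

Taking that single step as a weak guide, the loss of a chloro from compound 2 at 87500 nM is expected to raise the number modestly, toward weaker inhibition of growth. The expected size is a 1.9-fold higher number from compound 2 to compound 3 (0.29 log units; within the scatter) as an estimate. Compound 3 is estimated at 170000 nM with 50000 nM to 550000 nM as the expected range.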

Compound 3, concentration for 50% growth inhibition: 121000 nM
Compound 3: the middle estimate sits 1.4-fold (0.15 log units) above what was measured; the measured number falls inside the stated range.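

In this assay, the exchange of 4-chlorophenyl for 4-methoxyphenyl gives a 1.4-fold higher number from compound 2 to compound 3 (0.14 log units; within the scatter), so on this read-out the two groups cannot be told apart at this position. Among these compounds, this is the first measured step to touch the position at all, as compound 1 and compound 2 both carry the 4-chlorophenyl group and could say nothing about what happens when its chloro leaves. It is also the first step read between two actual numbers, whereas the only earlier step starts from a limit: the limit of > 652000 nM in this assay, at which 1 of the 3 values shown sits.

The compounds shown leave open whether any other group at this position, such as a hydroxyl, a nitrile or a longer alkoxy chain, or plain hydrogen, would move the number beyond the scatter, since chloro and methoxy are the only two substituents seen here. Among the compounds shown here, also open is whether methoxy in place of the chloro on the other aromatic ring, where the one earlier step was seen, would likewise leave the number within the scatter.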